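The source may hold more compounds than are shown below. What is called first, only, known or untested is meant among the compounds shown, and "the series" means these compounds.

Measured compounds:
compound 1 `CCCNS(=O)(=O)c1ccc(Nc2ncc3c(n2)N(C2CCCC2)[C@H](CC)C(=O)N3C)cc1` gives 344 nM in a functional assay on MCF7 cells (Homo sapiens) for antiproliferative activity, read by CCK-8 assay, with a stated time of 72 h; on this read-out higher numbers stand for weaker inhibition of growth and lower numbers for stronger inhibition of growth
compound 2 `CCCCNC(=O)c1ccc2c(ccn2-c2ncc3c(n2)N(C2CCCC2)[C@H](CC)C(=O)N3C)c1` gives 634 nM in this assay

Compound 1 and compound 2 lie within the usual scatter of each other, so the two numbers do not separate them. Compound 3 `CC[C@@H]1C(=O)N(C)c2cnc(Nc3ccc(S(=O)(=O)Nc4ccccc4)cc3)nc2N1C1CCCC1` is the untested partner of compound 1; the difference is phenyl in place of propyl on a sulfonamide nitrogen. For the measured compounds named here, no step between measured compounds bears on this change, so there is nothing to set its size from. The step from compound 1 to compound 3 is expected to stay inside the scatter, as a 1.2-fold higher number from compound 1 to compound 3 (0.07 log units; within the scatter). Compound 3 is therefore estimated at 400 nM, with a range from 120 nM to 1300 nM.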

Compound 3, concentration for 50% growth inhibition: 5430 nM
Beside the measured number, compound 3's estimate is 14-fold (1.13 log units) below it; measured number outside the range, above it.
By their numbers in this assay, from the lowest: compounds 1 and 2 (each within the scatter of the next); then compound 3.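

The sulfonamide nitrogen does not accept just any group: in this assay, phenyl in place of propyl gives a 16-fold higher number from compound 1 to compound 3 (1.20 log units; beyond the scatter) and so clearly weakens growth inhibition. This single change shows that the group on this nitrogen can strongly affect the result, which compounds 1 and 2 alone could not show, as they differ in more than one place. Nothing available here explains the loss.

From the compounds shown here alone, it remains open whether the aromatic ring or simply the larger group matters. A cyclohexyl or benzyl group on the same nitrogen could help separate those two possibilities.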